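A few compounds are considered here, and "the series" means these few. Any claim that something is new, unique, unknown or untested is made for them only; others in the source may bear on it.

In a physicochemical assay for lipophilicity, at pH 7.4 (on this read-out lower numbers stand for lower lipophilicity and higher numbers for higher lipophilicity), compound 1 `CCc1ccc(N(CC(C)C)S(=O)(=O)c2ccc3c(c2)C(=O)CC(C2CCN(S(=O)(=O)C4CCCC4)CC2)O3)cc1` gives 4.75, the second highest of three measured numbers. Compound 2 `CCc1ccc(N(CC(C)C)S(=O)(=O)c2ccc3c(c2)C(=O)C[C@@H](C2CCOCC2)O3)cc1` sits lower at 4.2, while compound 3 `CCc1ccc(N(CC(C)C)S(=O)(=O)c2ccc3cc(OCC4CCOCC4)c(C(=O)OC)cc3c2)cc1` sits higher at 6.09, and both gaps from compound 1 lie beyond the scatter.

The next compound to consider is compound 4 `CCc1ccc(N(CC(C)C)S(=O)(=O)c2ccc3c(c2)C(=O)CC(C2CCNCC2)O3)cc1`, which differs from compound 1 in a single place: hydrogen in place of cyclopentylsulfonyl on an amine nitrogen in a ring. In words, hydrogen stands in place of cyclopentylsulfonyl on an amine nitrogen in a ring, so a sizeable group is removed and nothing of comparable size replaces it.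

For the measured compounds named here, no measured pair shows this change on its own, which makes any forecast rough. Compound 2, which also lacks the cyclopentylsulfonyl group, gives 4.2, and this offers only a loose guide. A large drop beyond the scatter is expected in this assay, taking compound 4 below compound 2 as well. The estimated step is a number 1.95 log units lower from compound 1 to compound 4 (beyond the scatter). For compound 4 the estimated value is 2.8, within an expected range from 2 to 3.6.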

Compound 4, distribution coefficient: 2.21
Beside the measured number, compound 4's estimate is 0.59 log units above it; the measured number falls inside the stated range.
By their numbers in this assay, from the lowest: compound 4; then compound 2; then compound 1; then compound 3.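

For the compounds shown here, replacing cyclopentylsulfonyl with hydrogen on the amine nitrogen in a ring gives, in this assay, a number 2.54 log units lower from compound 1 to compound 4 (beyond the scatter) as the first reading of this change on its own. The rest of the molecule stays the same across this pair, so a single place, three ring bonds from the ring atom that bears a large group, accounts for a large step in the read-out. Nothing measured here explains the size of this step.

With only these two groups compared on this nitrogen, the compounds shown cannot separate the part played by the sulfonyl from that of the five-membered carbon ring. A methyl group, an acetyl group or a methylsulfonyl group at the same nitrogen would show where between these two ends the read-out falls.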